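Trimming Propyl to Ethyl: Expected Cytotoxicity of Compound 4

The source may report more compounds than this note shows. Statements on the series, on what has been measured and on what is new or still open speak of the compounds shown alone.

Of the compounds shown here, three built on one shared core have been tested in an ADME assay on MDCK cells (Canis lupus familiaris) for cytotoxicity, read by microscopy, with a stated time of 48 h; a lower number here means that less compound is tolerated, a higher number that more compound is tolerated. Compound 1 `C[C@H]1[C@H](NCc2sccc2-c2ccccc2)C[C@H]2C[C@@H]1C2(C)C` gives 12500 nM. Compound 2 `C[C@H]1[C@H](NCc2sccc2-c2ccsc2)C[C@H]2C[C@@H]1C2(C)C` gives 12500 nM. Compound 3 `CCCc1ccsc1CN[C@@H]1C[C@H]2C[C@@H]([C@H]1C)C2(C)C` gives 50000 nM, the highest of the three numbers, so it is the compound whose presence cells tolerate at the greatest concentration. Two steps lead to it: a 4.0-fold higher number from compound 1 to compound 3 (0.60 log units; beyond the scatter) and a 4.0-fold higher number from compound 2 to compound 3 (0.60 log units; beyond the scatter). By contrast, no change at the digits printed from compound 1 to compound 2 (within the scatter).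

Compound 4 `CCc1ccsc1CN[C@@H]1C[C@H]2C[C@@H]([C@H]1C)C2(C)C` is the next compound to be measured in this assay. It differs from compound 3 by hydrogen in place of methyl on a saturated chain carbon, two bonds along the chain from an aromatic carbon. Among the compounds with values here, no measured step matches this kind of change. The two steps that reach compound 3 replace a whole aromatic ring with a propyl chain, a far larger structural move than taking a single methyl off the end of that chain. With only those larger steps as background, the small trim is expected to leave the number close to where compound 3 stands, and the step of no change at the digits printed from compound 3 to compound 4 (within the scatter) is therefore expected to fall within the scatter rather than beyond it. Compound 4 is estimated to give 50000 nM in this assay, with a range from 25000 nM to 100000 nM.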

Compound 4, minimum cytotoxic concentration: 25000 nM
For compound 4 the middle estimate is 2.0-fold (0.30 log units) above the measured one; low and high end bracket the measured number.
By their numbers in this assay, from the lowest: compounds 1, 2, 4 and 3 (each within the scatter of the next, the first and the last beyond it).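

Trimming propyl to ethyl, with hydrogen in place of methyl on a saturated chain carbon, two bonds along the chain from an aromatic carbon, gives a 2.0-fold lower number from compound 3 to compound 4 (0.30 log units; within the scatter) in this assay, the first measured change confined to this chain, and it stays inside the normal noise of the measurement. The ethyl compound also cannot be told apart from either ring-bearing compound, with a 2.0-fold higher number from compound 2 to compound 4 (0.30 log units; within the scatter) and a 2.0-fold higher number from compound 1 to compound 4 (0.30 log units; within the scatter), so the clear separation seen earlier between propyl and the two rings now has a compound sitting within the scatter of both sides. Nothing measured here offers a reason for these numbers.

The compounds shown leave open how a methyl group or a longer butyl chain in this same place would read, and so whether chain length follows any trend at all, given that only propyl and ethyl can be compared so far. They also leave open whether an amine or a hydroxyl group at the end of the chain would move the number beyond the scatter.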